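A few compounds are considered here, and "the series" means these few. Any claim that something is new, unique, unknown or untested is made for them only; others in the source may bear on it.

Of the compounds shown here, two have been measured in an assay on isolated protein for inhibition of Polyunsaturated fatty acid 5-lipoxygenase (Homo sapiens), read by ELISA (on this read-out lower numbers stand for stronger inhibition and higher numbers for weaker inhibition), so far, and their numbers sit close together. Compound 2 `CC(C)(C)c1cc(/C=N/NC(=O)c2ccccc2)c(O)c(C(C)(C)C)c1` gives 5880 nM in this assay, the lowest of the two numbers, with compound 1 `CC(C)(C)c1cc(/C=N/NC(=O)c2ccncc2)c(O)c(C(C)(C)C)c1` nearest at 6250 nM. Among the measured compounds shown here, the single step between them, a 1.1-fold lower number from compound 1 to compound 2 (0.03 log units; within the scatter), puts phenyl in place of pyridin-4-yl on the carbonyl carbon, and its size is within the scatter, so the two values cannot be told apart.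

Compound 3 `CC(C)(C)c1cc(/C=N/NC(=O)c2cccnc2)c(O)c(C(C)(C)C)c1` is not yet measured. Relative to compound 2 the change is pyridin-3-yl in place of phenyl on a carbonyl carbon. For the measured compounds named here, the one step that bears on it is the phenyl-for-pyridin-4-yl exchange from compound 1 to compound 2, where the ring nitrogen made no difference beyond the scatter; compound 3 carries a pyridin-3-yl instead, a ring with the same atom count and one acceptor. Since the measured change of the same kind, a 1.1-fold lower number from compound 1 to compound 2 (0.03 log units; within the scatter), was within the scatter, no step beyond the scatter is expected here either, and the estimate for compound 3 is a 1.0-fold higher number from compound 2 to compound 3 (0.01 log units; within the scatter). Compound 3 is therefore expected to give about 6000 nM, within a range from 3000 nM to 12000 nM.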

Compound 3, half-maximal inhibitory concentration: 5550 nM
For compound 3 the middle estimate is 1.1-fold (0.03 log units) above the measured one; the range from low to high includes it.
By their numbers in this assay, from the lowest: compounds 3, 2 and 1 (each within the scatter of the next).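

In this assay, the ring on the carbonyl carbon now exists in three forms, and the step of a 1.1-fold lower number from compound 2 to compound 3 (0.03 log units; within the scatter) shows that pyridin-3-yl, like pyridin-4-yl before it, cannot be told apart from phenyl at this place. The comparison of the two nitrogen-containing rings, which the earlier pair could not offer, gives a 1.1-fold lower number from compound 1 to compound 3 (0.05 log units; within the scatter), so changing which pyridine ring is attached also leaves no readable difference. Nothing available here explains why these ring exchanges leave the read-out unchanged.

Going by these compounds, all three groups are six-membered aromatic rings with the same heavy-atom count, so it remains open whether this place would respond to something of a different kind, such as a saturated piperidine ring, a phenyl ring carrying a carboxylic acid or an amine, or a longer alkyl chain. The rest of the structure is also identical across compounds 1, 2 and 3, which leaves open what would happen if, for example, the tert-butyl groups of the shared core gave way to methyl groups.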